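The source may hold more compounds than are shown below. What is called first, only, known or untested is meant among the compounds shown, and "the series" means these compounds.

Measured in a toxicity assay on THLE-2 cells (Homo sapiens) for cytotoxicity, read by MTT assay, with a stated time of 72 h; a higher number here means that more compound is tolerated, a lower number that less compound is tolerated:
- compound 1 `CC(C)OC(=O)c1sc(Nc2ncccn2)nc1-c1cnccn1`: 50000 nM
- compound 2 `CC(C)OC(=O)c1sc(Nc2ncccn2)nc1-c1ccncn1`: 46200 nM

On these numbers, compound 2 at 46200 nM cannot be told apart from compound 1. Compound 3 `CC(C)OC(=O)c1sc(Nc2ncccn2)nc1-c1ncccn1` carries pyrimidin-2-yl in place of pyrimidin-4-yl on an aromatic carbon. Within the data shown here, only one measured step bears on this swap of one ring for a closely related one, namely a 1.1-fold lower number from compound 1 to compound 2 (0.03 log units; within the scatter). That single step is small, so no change beyond the scatter is expected in this assay, and the direction is open. The expected step is a 1.0-fold lower number from compound 2 to compound 3 (0.01 log units; within the scatter). Compound 3 is expected at 45000 nM, with an estimated range of 22000 nM to 90000 nM.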

Compound 3, half-maximal cytotoxic concentration: 50000 nM
Compound 3: the middle estimate sits 1.1-fold (0.05 log units) below what was measured; measured number inside the range.
By their numbers in this assay, from the lowest: compounds 2, 1 and 3 (each within the scatter of the next).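

In this assay the swap to pyrimidin-2-yl gives a 1.1-fold higher number from compound 2 to compound 3 (0.03 log units; within the scatter) and no change at the digits printed from compound 1 to compound 3 (within the scatter) on this aromatic carbon of the five-membered ring. With a third ring now measured at this position, pyrazin-2-yl, pyrimidin-4-yl and pyrimidin-2-yl cannot be told apart in these cells, which one step alone could not show. Nothing measured here explains this sameness. Still open, from the compounds shown here alone, is whether a plain phenyl ring, or one carrying an amine or a carboxylic acid, would move the number beyond the scatter.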